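Aryl ester exchange in a cytotoxicity series

The source may hold more compounds than are shown below. What is called first, only, known or untested is meant among the compounds shown, and "the series" means these compounds.

Compound 3 `COC(=O)c1c(Cl)cccc1OC(=O)COc1cc(O)c2c(=O)cc(-c3ccccc3)oc2c1` gives 366000 nM in an ADME assay on cells (T-cell, Mus musculus, strain BALB/c) for cytotoxicity, read by MTT assay, with a stated time of 48 h (a higher number here means that more compound is tolerated, a lower number that less compound is tolerated), level with compound 2 `COC(=O)c1cccc(Cl)c1OC(=O)COc1cc(O)c2c(=O)cc(-c3ccccc3)oc2c1` at 366000 nM and together the highest of the three numbers, while compound 1 `COC(=O)c1c(C)cccc1OC(=O)COc1cc(O)c2c(=O)cc(-c3ccccc3)oc2c1` stands at 298000 nM. Compound 4 `COC(=O)c1cc(C)ccc1OC(=O)COc1cc(O)c2c(=O)cc(-c3ccccc3)oc2c1` differs from compound 3 in one place: a group of 11 heavy atoms (9 carbon, 2 oxygen; one six-membered aromatic ring of carbon only) in place of a group of 11 heavy atoms (8 carbon, 2 oxygen, 1 chlorine; one six-membered aromatic ring of carbon only), on an oxygen next to a carbonyl group. The measured steps that bear on this change are all exchanges at the same oxygen next to a carbonyl group, and they were a 1.2-fold higher number from compound 1 to compound 2 (0.09 log units; within the scatter), a 1.2-fold higher number from compound 1 to compound 3 (0.09 log units; within the scatter) and no change at the digits printed from compound 2 to compound 3 (within the scatter), none of them beyond the scatter. For compound 4 the expected step is therefore a 1.1-fold lower number from compound 3 to compound 4 (0.03 log units; within the scatter), nothing beyond the scatter. Compound 4 is estimated at 340000 nM in this assay, with a range from 160000 nM to 720000 nM.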

Compound 4, half-maximal cytotoxic concentration: 306000 nM
Estimate against measurement, compound 4: 1.1-fold (0.05 log units) above; measured number inside the range.
By their numbers in this assay, from the lowest: compounds 1, 4, 2 and 3 (each within the scatter of the next).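

On the oxygen next to a carbonyl group in this assay, the group that enters in compound 4 gives a 1.2-fold lower number from compound 3 to compound 4 (0.08 log units; within the scatter), a 1.2-fold lower number from compound 2 to compound 4 (0.08 log units; within the scatter) and a 1.0-fold higher number from compound 1 to compound 4 (0.01 log units; within the scatter). For the compounds shown here, compound 4 thus adds a fourth aryl group at this place, and no step among the four compounds lies beyond the scatter. No measurement offers an explanation for this result. The compounds shown leave open whether an aryl group carrying an amine or a carboxylic acid instead of methoxycarbonyl, or a longer chain on this oxygen, would step beyond the scatter.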